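The source may report more compounds than this note shows. Statements on the series, on what has been measured and on what is new or still open speak of the compounds shown alone.

Compounds measured in a toxicity assay on HEK-293T cells (Homo sapiens) for cytotoxicity, read by MTT assay, with a stated time of 48 h; on this read-out lower numbers stand for stronger inhibition and higher numbers for weaker inhibition:
compound 1 `C=C1[C@H](OC(C)=O)[C@@H](OC(C)=O)[C@@H](OC(C)=O)C(C)(C)/C=C/[C@H](C)[C@H](OC(=O)c2ccccc2)[C@@]2(O)C[C@@](C)(O)[C@H](OC(C)=O)[C@@H]2[C@H]1OCC(C)C` gives 39300 nM
compound 2 `C=C1[C@H](O)[C@@H](OC(=O)C(C)(C)C)[C@@H](O)C(C)(C)/C=C/[C@H](C)[C@H](OC(=O)c2ccccc2)[C@@]2(O)C[C@@](C)(O)[C@H](OC(C)=O)[C@@H]2[C@H]1OCC(C)C` gives 31700 nM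
compound 3 `C=C1[C@H](OC(C)=O)[C@@H](OC(C)=O)[C@@H](OC(C)=O)C(C)(C)/C=C/[C@H](C)[C@H](OC(=O)c2ccccc2)[C@@]2(O)C[C@@](C)(OC(=O)c3ccncc3)[C@H](OC(C)=O)[C@@H]2[C@H]1OCC(C)C` gives 19500 nM

Compound 3 holds the lowest of the three numbers, yet both its neighbours sit within the scatter of it, so no order among the three can be read. Compound 4 `C=C1[C@H](OC(C)=O)[C@@H](OC(C)=O)[C@@H](OC(C)=O)C(C)(C)/C=C/[C@H](C)[C@H](OC(=O)c2ccccc2)[C@@]2(O)C[C@@](C)(OC(=O)c3cccc(C)c3)[C@H](OC(C)=O)[C@@H]2[C@H]1OCC(C)C` differs from compound 3 by 3-methylphenyl in place of pyridin-4-yl on a carbonyl carbon. Going by the values given here, the only single-point step available, a 2.0-fold lower number from compound 1 to compound 3 (0.30 log units; within the scatter), concerns the arrival of the whole acyl group on the oxygen and stayed within the scatter; no measured step exchanges one aryl for another on that carbonyl carbon. The change to compound 4 is therefore expected to give a step of about a 1.0-fold higher number from compound 3 to compound 4 (0.01 log units; within the scatter) in this assay, none beyond the scatter. Compound 4 is estimated at 20000 nM, with a range from 8000 nM to 50000 nM.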

Compound 4, half-maximal inhibitory concentration: 7220 nM
Beside the measured number, compound 4's estimate is 2.8-fold (0.44 log units) above it, and the stated range ends above it.
By their numbers in this assay, from the lowest: compound 4; then compounds 3, 2 and 1 (each within the scatter of the next).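

In this assay, going by these compounds alone, the group on this carbonyl carbon now counts: 3-methylphenyl in place of pyridin-4-yl gives a 2.7-fold lower number from compound 3 to compound 4 (0.43 log units; beyond the scatter), a step beyond the scatter where the earlier compounds showed none. Acylation of the oxygen on a saturated carbon likewise gives a 5.4-fold lower number from compound 1 to compound 4 (0.74 log units; beyond the scatter) with (3-methylphenyl)carbonyl, whereas the (pyridin-4-yl)carbonyl step stayed within the scatter. Nothing available accounts for these steps.

The two aryl groups differ in both the methyl and the ring nitrogen, so an unsubstituted phenyl on this carbonyl carbon remains the open comparison. Also open, on these data alone, is how an amine or a longer alkyl chain would read there.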